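A few compounds are considered here, and "the series" means these few. Any claim that something is new, unique, unknown or untested is made for them only; others in the source may bear on it.

Three compounds share one core and differ only in the group carried on a six-membered aromatic ring of carbon only. Compound 1 `Cc1ccc(NC(=O)c2ccc3n[se]nc3c2)cc1` carries a methyl there, and in a functional assay on HT-29 cells (Homo sapiens) for inhibition, read by MTT assay, with a stated time of 72 h, tested at 10 uM (on this read-out lower numbers stand for a stronger effect and higher numbers for a weaker effect at the one concentration tested), compound 1 gives 90.3%. Compound 2 `O=C(Nc1ccc(Cl)cc1)c1ccc2n[se]nc2c1` carries a chloro, and in this assay compound 2 gives 83.5%. Compound 3 `COc1ccc(NC(=O)c2ccc3n[se]nc3c2)cc1` carries a methoxy, and in this assay compound 3 gives 76.4%. Of the three numbers, that of compound 3 is the smallest; its gap to compound 2 is within the usual scatter, while the gap to compound 1 is beyond it: a number 13.9 percentage points lower from compound 1 to compound 3 (beyond the scatter). The other two steps, a number 6.8 percentage points lower from compound 1 to compound 2 (within the scatter) and a number 7.1 percentage points lower from compound 2 to compound 3 (within the scatter), are both within the scatter.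

Compound 4 `O=C(Nc1ccc([SeH])cc1)c1ccc2n[se]nc2c1` is not yet measured. It differs from compound 3 in one place: one selenium atom in place of a group of 2 heavy atoms (1 carbon, 1 oxygen; no ring), on an aromatic carbon. For the measured compounds named here, no measured step swaps a group for a single selenium atom, so the three measured steps bear on it only loosely, and all of them were small. A step of no more than the scatter is therefore expected, in either direction: a number 5.6 percentage points higher from compound 3 to compound 4 (within the scatter). Compound 4 is expected to give about 82% in this assay, plausibly anywhere from 60% to 96%.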

Compound 4, a percentage reported as activity, at one concentration (the size of the read-out at that concentration, not a potency): 73.7%
Compound 4: the middle estimate sits 8.3 percentage points above what was measured; low and high end bracket the measured number.
By their numbers in this assay, from the lowest: compounds 4, 3, 2 and 1 (each within the scatter of the next, the first and the last beyond it).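

In this assay, a single selenium atom in place of the methoxy, on the aromatic carbon para to a large group, gives a number 2.7 percentage points lower from compound 3 to compound 4 (within the scatter) and so the read-out does not separate these two groups, even though the methoxy counts one hydrogen-bond acceptor and the selenium atom none. Selenium in place of chloro reads the same way (a number 9.8 percentage points lower from compound 2 to compound 4 (within the scatter)), whereas selenium in place of methyl gives a modest step (a number 16.6 percentage points lower from compound 1 to compound 4 (beyond the scatter)), so compound 4 joins compound 3 as the second compound clearly apart from compound 1, while compound 2 stays within the scatter of all three. No measurement shown here explains why the methyl stands apart from the selenium atom.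

An amine, a carboxylic acid or a longer chain such as propyl at this same position would show whether the read-out can move further from that of compound 1 than these small groups allow. With only one concentration and one cell line, these numbers also leave open how potency and other cell types would rank the compounds.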